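Amide and sulfonamide pairs in a biphenyl ether series

This account rests on a few compounds, and the source may have more. Where it says the series, first, only, none or still open, it means among the compounds named here.

Measured so far:
Compound 1, `CCNS(=O)(=O)c1cccc(-c2ccc(OCC)cc2)c1`, 46%
Compound 2, `CCOc1ccc(-c2cccc(S(=O)(=O)NC)c2)cc1`, 47%
Compound 3, `CCOc1ccc(-c2cccc(C(=O)NC)c2)cc1`, 40%

All three were tested in an assay on COS-7 cells for inhibition of patatin-like phospholipase domain-containing protein 2 (Mus musculus), tested at 200 uM; on this read-out higher numbers stand for more inhibition at the one concentration tested (going by the name of the read-out) and lower numbers for less inhibition. Compound 2 and compound 1 differ by methyl in place of hydrogen on a saturated chain carbon bound to a sulfonamide nitrogen; this gave a number 1 percentage points lower from compound 2 to compound 1 (within the scatter). Compound 2 and compound 3 differ in the core, by methylcarbamoyl in place of methylsulfamoyl on an aromatic carbon, with a number 7 percentage points lower from compound 2 to compound 3 (within the scatter), and a number 6 percentage points lower from compound 1 to compound 3 (within the scatter) covers the remaining pair.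

Compound 4, `CCNC(=O)c1cccc(-c2ccc(OCC)cc2)c1`, has not been measured in this assay. It differs from compound 3 by methyl in place of hydrogen on a saturated chain carbon bound to an amide-type nitrogen, the same kind of change as from compound 2 to compound 1, but here the place is a saturated chain carbon bound to an amide-type nitrogen rather than to a sulfonamide nitrogen. Because the earlier change gave only a number 1 percentage points lower from compound 2 to compound 1 (within the scatter), a step of about no change at the digits printed from compound 3 to compound 4 (within the scatter) is expected. Compound 4 is therefore estimated at 40%, between 30% and 51%.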

Compound 4, a percentage reported as inhibition, at one concentration (the size of the read-out at that concentration, not a potency): 62%
For compound 4 the middle estimate is 22 percentage points below the measured one; measured number outside the range, above it.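

In this assay the step on the amide core, a number 22 percentage points higher from compound 3 to compound 4 (beyond the scatter), does not match the step on the sulfonamide core: the same change on two cores in this assay, a number 1 percentage points lower (within the scatter) from compound 2 to compound 1 and a number 22 percentage points higher (beyond the scatter) from compound 3 to compound 4, 23 percentage points apart, beyond the scatter of two such steps. Compound 4 also stands apart from both sulfonamides, with a number 15 percentage points higher from compound 2 to compound 4 (beyond the scatter) and a number 16 percentage points higher from compound 1 to compound 4 (beyond the scatter). This shows that the methyl change cannot be carried unchanged between these two cores, but with one pair per core at a single concentration, it does not show how the change would run on any other core.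

The compounds shown leave open whether a propyl chain in place of the ethyl of the ethylcarbamoyl group would follow the same trend. As far as these compounds go, a cyclopropyl group in that place also remains open.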